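This account rests on a few compounds, and the source may have more. Where it says the series, first, only, none or still open, it means among the compounds named here.

In an ADME assay on MDBK cells (Bos taurus) for cytotoxicity, read by MTT assay, with a stated time of 96 h (a lower number here means that less compound is tolerated, a higher number that more compound is tolerated), compound 1 `Fc1ccc(F)c(/N=N/Nc2ccccc2)c1` reads > 100000 nM, which is a limit of the assay. Among the compounds with values here, compound 2 `CN(C)CCCN(/N=N/c1cc(F)ccc1F)c1ccccc1` gives 25000 nM, the only actual number so far. Within the data shown here, the sole measured step, an at least 4.0-fold lower number from compound 1 to compound 2 (0.60 log units; beyond the scatter), places 3-(dimethylamino)propyl on a nitrogen, not on an aromatic carbon, so it offers only weak guidance here. Compound 3 `CN(C)CCCN(/N=N/c1cc(F)ccc1F)c1cccc(C(F)(F)F)c1` has trifluoromethyl in place of hydrogen on an aromatic carbon, (trifluoromethyl in place of hydrogen on an aromatic carbon). With nothing measured at that place, the change is expected to stay within the scatter in this assay, leaning slightly towards a lower number: a 1.4-fold lower number from compound 2 to compound 3 (0.14 log units; within the scatter). Compound 3 is estimated at 18000 nM, with an expected range of 7000 nM to 50000 nM.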

Compound 3, half-maximal cytotoxic concentration: > 100000 nM
Compound 3 was reported as a limit; the forecaster's own chance of this, stated with the estimate: 8%; at least 5.5-fold (0.74 log units) between middle value and limit.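

In this assay, trifluoromethyl in place of hydrogen on an aromatic carbon, meta to a large group, gives an at least 4.0-fold higher number from compound 2 to compound 3 (0.60 log units; beyond the scatter), the first sign that this position responds to substitution. Compound 3 gives > 100000 nM, which is a limit and not a number. The size of this step therefore has only a lower bound, and the reading for compound 3 rests at the same limit as another compound: the limit of > 100000 nM in this assay, at which 2 of the 3 values shown sit.

From the compounds shown here alone, whether a methyl group, a chlorine atom or a carboxylic acid on this aromatic carbon would move the number the same way stays open.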